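Moving Away from the Low Point of Compound 3

The compounds below may be only part of what the source reports. "The series", "measured", "known", "first", "only" and "open" are said of these compounds alone.

Three measured compounds share one core. In an ADME assay on S9 fraction from liver (Rattus norvegicus) for metabolic stability, with a stated time of 1 h (on this read-out higher numbers stand for a more stable compound and lower numbers for a less stable compound), compound 1 `N#Cc1cnc(NCc2cnccc2C(F)(F)F)cc1N[C@H]1C[C@@H](O)C1` gives 70% and compound 2 `N#Cc1cnc(NCc2cnccc2C(F)(F)F)cc1N[C@H]1C[C@H](O)C1` gives 82%. The pair shows a number 12 percentage points higher from compound 1 to compound 2 (beyond the scatter), which comes with the fact that compounds 1 and 2 differ only in the configuration as drawn. Compound 3 `CO[C@H]1CC[C@@H](CNc2cc(NCc3cnccc3C(F)(F)F)ncc2C#N)CC1` stands lowest of the three at 2%, and the steps to it are large: a number 68 percentage points lower from compound 1 to compound 3 (beyond the scatter) and a number 80 percentage points lower from compound 2 to compound 3 (beyond the scatter).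

Compound 4 `CNC(=O)[C@H]1CC[C@@H](Nc2cc(NCc3cnccc3C(F)(F)F)ncc2C#N)CC1` has not yet been measured. The change is 4-(methylcarbamoyl)cyclohexyl in place of (4-methoxycyclohexyl)methyl on a nitrogen on an aromatic ring, with 4-(methylcarbamoyl)cyclohexyl in place of (4-methoxycyclohexyl)methyl on a nitrogen on an aromatic ring. For the measured compounds named here, no measured step makes this exact swap. Compound 4 gives up the group seen in a number 80 percentage points lower from compound 2 to compound 3 (beyond the scatter), so part of that fall should be recovered. A large rise is therefore expected, a number 48 percentage points higher from compound 3 to compound 4 (beyond the scatter). Going by the values given here, the entering group has no measured example, which keeps the range wide. Compound 4 is estimated at 50%, with an expected range from 20% to 80%.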

Compound 4, percent of the compound remaining: 53%
For compound 4 the middle estimate is 3 percentage points below the measured one, within the range that was stated.
By their numbers in this assay, from the lowest: compound 3; then compound 4; then compound 1; then compound 2.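

In this assay, a six-membered carbon ring on this nitrogen does not by itself bring the very low number of compound 3: with 4-(methylcarbamoyl)cyclohexyl in place of (4-methoxycyclohexyl)methyl, the result is a number 51 percentage points higher from compound 3 to compound 4 (beyond the scatter). The smaller 3-hydroxycyclobutyl group still keeps the lead, with a number 29 percentage points lower from compound 2 to compound 4 (beyond the scatter) and a number 17 percentage points lower from compound 1 to compound 4 (beyond the scatter), so much of the fall is recovered, but not all of it. The only fact at hand concerns the drawn configuration of compounds 1 and 2, and it offers no explanation for this result.

The leaving and entering groups differ in more than one feature, so the shift cannot be tied to any single one of them. A 4-aminocyclohexyl or 4-carboxycyclohexyl group on the same nitrogen would show how far the number depends on the methylcarbamoyl group itself.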